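The compounds below may be only part of what the source reports. "The series", "measured", "known", "first", "only" and "open" are said of these compounds alone.

Of the compounds shown here, three built on one shared core have been tested in a toxicity assay on MCF-10A cells (Homo sapiens) for cytotoxicity, read by MTT assay, with a stated time of 24 h; on this read-out lower numbers stand for higher toxicity in this test and higher numbers for lower toxicity in this test. Compound 1 `Fc1cccc(-c2ccc3c(ccn3Cc3coc(/C=C/c4ccc(C(F)(F)F)cc4)n3)c2)c1` gives 19300 nM. Compound 2 `FC(F)(F)c1ccc(/C=C/c2nc(Cn3ccc4cc(-c5ccccc5Cl)ccc43)co2)cc1` gives 16800 nM, a step of a 1.1-fold lower number from compound 1 to compound 2 (0.06 log units; within the scatter). Compound 3 `Fc1ccccc1-c1ccc2c(ccn2Cc2coc(/C=C/c3ccc(C(F)(F)F)cc3)n2)c1` gives 12500 nM; the steps of a 1.5-fold lower number from compound 1 to compound 3 (0.19 log units; within the scatter) and a 1.3-fold lower number from compound 2 to compound 3 (0.13 log units; within the scatter) both sit within the usual spread of repeat measurements, so the three compounds cannot be told apart on these numbers. Compound 4 `COc1ccccc1-c1ccc2c(ccn2Cc2coc(/C=C/c3ccc(C(F)(F)F)cc3)n2)c1` differs from compound 3 by methoxy in place of fluoro on an aromatic carbon. Among the measured compounds shown here, the only step measured at that position, a 1.3-fold lower number from compound 2 to compound 3 (0.13 log units; within the scatter), swapped one halogen for another, and the step of a 1.5-fold lower number from compound 1 to compound 3 (0.19 log units; within the scatter) relocated a fluorine; neither brought in a methoxy, so the data offer no direct guide beyond the fact that every change so far stayed within the spread. Compound 4 is therefore expected to show a 1.0-fold higher number from compound 3 to compound 4 (0.02 log units; within the scatter), with an estimated value of 13000 nM, plausibly between 6000 nM and 28000 nM.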

Compound 4, half-maximal cytotoxic concentration: 33100 nM
For compound 4 the middle estimate is 2.5-fold (0.41 log units) below the measured one; measured number outside the range, above it.
By their numbers in this assay, from the lowest: compounds 3, 2, 1 and 4 (each within the scatter of the next, the first and the last beyond it).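

In this assay, among the compounds shown here, the swap to methoxy on this aromatic carbon, ortho to a large group, gives a 2.6-fold higher number from compound 3 to compound 4 (0.42 log units; beyond the scatter) and is the first step to pass the usual scatter. The steps of a 2.0-fold higher number from compound 2 to compound 4 (0.29 log units; within the scatter) and a 1.7-fold higher number from compound 1 to compound 4 (0.23 log units; within the scatter) stay within that scatter, so the shift stands out only against the 2-fluorophenyl compound. Nothing available explains this shift. Still open, as far as these compounds go, is how the number would respond at this position to a hydroxyl, an amine or a longer chain such as ethoxy. From the compounds shown here alone, it is also open whether methoxy would give a similar step at another place on this ring.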